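Methoxy addition on two different cores, one partner unmeasured

The source may report more compounds than this note shows. Statements on the series, on what has been measured and on what is new or still open speak of the compounds shown alone.

Compound 1 `O=C(/C=C/c1ccccc1-c1ccc(F)nc1)c1cccc(O)c1` and compound 2 `COc1ccc(C(=O)/C=C/c2ccccc2-c2ccc(F)nc2)cc1O` share one core. Compound 3 `COc1ccc(CNC(=O)c2ccccc2-c2ccc(F)cc2)cc1` stands on another core; the difference between the two cores is not broken down here. Compound 4 `COc1ccc(CNC(=O)c2ccccc2-c2ccc(F)cc2)cc1OC` is the unmeasured partner of compound 3.

In a functional assay on HepG2 cells (Homo sapiens) for antiproliferative activity, read by sulforhodamine B assay, with a stated time of 48 h (on this read-out lower numbers stand for stronger inhibition and higher numbers for weaker inhibition), compound 1 gives 6400 nM. In this assay compound 2 gives 1800 nM. The change methoxy in place of hydrogen on an aromatic carbon made a 3.6-fold lower number from compound 1 to compound 2 (0.55 log units; beyond the scatter). For compound 3 this assay reports only a limit, > 50000 nM, which is the limit of > 50000 nM in this assay, at which 1 of the 3 values shown sits.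

From compound 3 to compound 4 the change is methoxy in place of hydrogen on an aromatic carbon. It is the same kind of change as in the measured pair, not the same: in compound 2 the entering methoxy sits ortho to a hydroxy group and para to a large group, while in compound 4 it sits ortho to a methoxy group and meta to a large group.

The measured pair gives one modest step of the same kind on a different core. Because the value of compound 3 is only a limit, any number for compound 4 is weakly founded. Compound 4 is expected to give 40000 nM in this assay, with a range from 10000 nM to 150000 nM. The step this estimate means is an at least 1.2-fold lower number from compound 3 to compound 4 (0.09 log units; that floor lies within the scatter). It is most likely that compound 4 again returns only a limit in this assay.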

Compound 4, half-maximal inhibitory concentration: > 50000 nM
Compound 4 was reported as a limit (the forecaster's own chance of this, stated with the estimate: 70%); at least 1.2-fold (0.09 log units) between middle value and limit.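

Compound 3 and compound 4 both stand at a limit in this assay, so no step can be read between them: the limit of > 50000 nM in this assay, at which 2 of the 4 values shown sit.

The compounds shown leave open whether methoxy in place of hydrogen on an aromatic carbon moves the number at all on the core of compound 3, as it did on the core of compound 1.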